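From a carboxy group to a five-membered nitrogen ring

The compounds below may be only part of what the source reports. "The series", "measured", "known", "first", "only" and "open" are said of these compounds alone.

Measured so far:
compound 1, `O=C(O)c1cc(=O)c2ccc(OCCCN3CCC(=C(c4ccccc4)c4ccccc4)CC3)cc2o1`, 16.2 nM
compound 2, `O=C(O)c1cc(=O)c2ccc(OCCCN3CCC(C(O)(c4ccccc4)c4ccccc4)CC3)cc2o1`, 5.25 nM

In a functional assay (ileum) with Cavia porcellus as the target (on this read-out lower numbers stand for stronger inhibition and higher numbers for weaker inhibition), compound 2 gives the lower of the two numbers, with the value of compound 1 standing higher by a gap that lies beyond the scatter. Compound 3, `O=c1cc(C2N=NN=N2)oc2cc(OCCCN3CCC(C(O)(c4ccccc4)c4ccccc4)CC3)ccc12`, differs from compound 2 in one place: a group of 5 heavy atoms (1 carbon, 4 nitrogen; one five-membered non-aromatic ring with 4 hetero atoms) in place of a group of 3 heavy atoms (1 carbon, 2 oxygen; no ring), on an aromatic carbon. Among the compounds with values here, no measured pair shows this change, so its effect in this assay is unknown; the step from compound 2 to compound 3 is expected to be small, either way, and not beyond the scatter. Compound 3 is therefore estimated at 5.5 nM, within 1.5 nM to 20 nM, a step of a 1.0-fold higher number from compound 2 to compound 3 (0.02 log units; within the scatter).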

Compound 3, antagonist equilibrium constant: 1.7 nM
Beside the measured number, compound 3's estimate is 3.2-fold (0.51 log units) above it; the measured number falls inside the stated range.
By their numbers in this assay, from the lowest: compound 3; then compound 2; then compound 1.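

The position next to the ring oxygen, which carries the carboxy group in compound 1 and compound 2, proves open to a change of group: in this assay, replacing that carboxy group with the five-membered non-aromatic ring with 4 hetero atoms gives a 3.1-fold lower number from compound 2 to compound 3 (0.49 log units; beyond the scatter), and inhibition is stronger, not merely retained. The carboxy group, and the hydrogen-bond donor counted in it, is therefore not needed at this place for a low number on this read-out. Nothing measured here gives a reason for this step.

Going by these compounds, it remains open whether other groups at this position, such as a methyl ester or a primary amide, would match the ring in compound 3. Also open, on these data alone, is whether the same exchange would lower the number on the core of compound 1.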